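The source may hold more compounds than are shown below. What is called first, only, known or untested is meant among the compounds shown, and "the series" means these compounds.

Measured compounds:
compound 1 `O=C(Nc1ccccc1)C(=O)Nc1ccc2c(c1)COC2=O` — 36100 nM
compound 2 `O=C(Nc1ccc(F)cc1)C(=O)Nc1ccc2c(c1)COC2=O` — 570 nM
compound 3 `O=C(Nc1ccc(O)cc1)C(=O)Nc1ccc2c(c1)COC2=O` — 5030 nM

In a functional assay on cells (T-cell, Mus musculus) for inhibition (a higher number here means a weaker inhibitor, a lower number a stronger inhibitor), compound 1 gives the highest of the three numbers; compound 3 is its nearest neighbour and compound 2 the furthest. The next compound to be run in this assay is compound 4 `O=C(Nc1cccc([N+](=O)[O-])c1)C(=O)Nc1ccc2c(c1)COC2=O`, which differs from compound 1 in one place: nitro in place of hydrogen on an aromatic carbon.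

Within the data shown here, two measured steps bear on this change, both starting from compound 1 and both placing a single group on the same aromatic ring. Fluoro in place of hydrogen on an aromatic carbon gave a 63-fold lower number from compound 1 to compound 2 (1.80 log units; beyond the scatter); hydroxy in place of hydrogen on an aromatic carbon gave a 7.2-fold lower number from compound 1 to compound 3 (0.86 log units; beyond the scatter). Both steps lower the number beyond the scatter, but the nitro group enters at a different carbon, meta to a large group, so neither step is a direct precedent and the size is uncertain. On balance a lowering of the number is expected for compound 4, smaller than the fluoro step and closer to the hydroxy step, giving an expected 9.0-fold lower number from compound 1 to compound 4 (0.96 log units; beyond the scatter). The estimated value for compound 4 in this assay is 4000 nM, with a range from 1000 nM to 20000 nM.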

Compound 4, half-maximal inhibitory concentration: 1820 nM
For compound 4 the middle estimate is 2.2-fold (0.34 log units) above the measured one; measured number inside the range.
By their numbers in this assay, from the lowest: compound 2; then compound 4; then compound 3; then compound 1.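

In this assay, a 20-fold lower number from compound 1 to compound 4 (1.30 log units; beyond the scatter) shows that the lowering of the number is not confined to the carbon carrying the fluoro and hydroxy groups: a group on an aromatic carbon meta to a large group also gives a step beyond the scatter. The step's size lies between a 7.2-fold lower number from compound 1 to compound 3 (0.86 log units; beyond the scatter) and a 63-fold lower number from compound 1 to compound 2 (1.80 log units; beyond the scatter), so all three groups placed on this ring lower the number from that of compound 1, and none of the compounds shown goes against this. Nothing measured here accounts for the size of the nitro step or for the order of the three steps.

Group and position remain entangled, as nitro sits at a different carbon from fluoro and hydroxy, so the difference between these steps cannot be assigned to either one alone. Also open, as far as these compounds go, are whether fluoro or hydroxy meta to a large group would match the nitro step, and whether an amine or a carboxylic acid at that carbon would lower the number at all.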